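The compounds below may be only part of what the source reports. "The series", "measured", "known", "first", "only" and "open" are said of these compounds alone.

Compound 1 `CC[C@H]1OC(=O)[C@H](C)[C@@H](O[C@H]2C[C@@](C)(OC)[C@@H](O)[C@H](C)O2)[C@H](C)[C@@H](O[C@@H]2O[C@H](C)C[C@H](N(C)C)[C@H]2OCCCN(C)Cc2ccnc3ccccc23)[C@](C)(O)C[C@@H](C)CN(C)[C@H](C)[C@@H](O)[C@]1(C)O`. In a physicochemical assay for solubility, at pH 4 (a higher number here means a more soluble compound, a lower number a less soluble compound), compound 1 gives > 10000 ug/mL, which is a limit of the assay rather than a number.
Compound 2 `CC[C@H]1OC(=O)[C@H](C)[C@@H](O[C@H]2C[C@@](C)(OC)[C@@H](O)[C@H](C)O2)[C@H](C)[C@@H](O[C@@H]2O[C@H](C)C[C@H](N(C)C)[C@H]2OCCCN(C)Cc2cnc3ccccc3c2)[C@](C)(O)C[C@@H](C)CN(C)[C@H](C)[C@@H](O)[C@]1(C)O`. In this assay compound 2 gives > 10000 ug/mL, again a limit of the assay.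
Compound 3 `CC[C@H]1OC(=O)[C@H](C)[C@@H](O)[C@H](C)[C@@H](O[C@@H]2O[C@H](C)C[C@H](N(C)C)[C@H]2OCCCNCc2ccnc3ccccc23)[C@](C)(O)C[C@@H](C)CN(C)[C@H](C)[C@@H](O)[C@]1(C)O`. In this assay compound 3 gives > 10000 ug/mL, likewise a limit.

All three measured values therefore sit at the same point, (the limit of > 10000 ug/mL in this assay, at which 3 of the 3 values shown sit). Compound 2 differs from compound 1 by quinolin-3-yl in place of quinolin-4-yl on a saturated chain carbon bound to an amine nitrogen; the step that the two limits leave unreadable from compound 1 to compound 2 cannot be read, since both ends of it are limits. Compound 3 carries a different core from compound 1, and the difference between the two cores is not broken down here.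

Compound 4 `CC[C@H]1OC(=O)[C@H](C)[C@@H](O)[C@H](C)[C@@H](O[C@@H]2O[C@H](C)C[C@H](N(C)C)[C@H]2OCCCNCc2cnc3ccccc3c2)[C@](C)(O)C[C@@H](C)CN(C)[C@H](C)[C@@H](O)[C@]1(C)O` is not yet measured. It differs from compound 3 by quinolin-3-yl in place of quinolin-4-yl on a saturated chain carbon bound to an amine nitrogen, the same change that turns compound 1 into compound 2, and at the same place. Because compound 3 gives > 10000 ug/mL and all measured values sit at the limit of > 10000 ug/mL in this assay, at which 3 of the 3 values shown sit, the step of a number no higher from compound 3 to compound 4 (the limit leaves the size open) is expected to be as unreadable as the earlier one, with compound 4 again expected above the assay's ceiling. Compound 4 is thus estimated at 10000 ug/mL in this assay, with a plausible range from 5000 ug/mL to 20000 ug/mL, and most likely only a limit will be reported.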

Compound 4, solubility: > 10000 ug/mL
Compound 4 ended at the assay's limit; the forecaster's own chance of this, stated with the estimate: 85%; the middle value lies on the limit itself.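

Compound 4, like compound 3, ends at a limit of the assay and not at a number, so the change from quinolin-4-yl to quinolin-3-yl cannot be read here, because both ends of the step are limits in this assay: the limit of > 10000 ug/mL in this assay, at which 4 of the 4 values shown sit.

The compounds shown leave open how far quinolin-3-yl and quinolin-4-yl differ in this assay, on either core, and how the two cores compare.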